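Pyrazinoyl in Place of Cyclohexylmethyl on the Ring Nitrogen

A few compounds are considered here, and "the series" means these few. Any claim that something is new, unique, unknown or untested is made for them only; others in the source may bear on it.

In an assay on CHO cells for displacement of a labelled ligand from Substance-P receptor (Homo sapiens) (on this read-out lower numbers stand for stronger inhibition and higher numbers for weaker inhibition), compound 1 `CN(Cc1cc(C(F)(F)F)cc(C(F)(F)F)c1)C(=O)[C@H]1CN(CC2CCCCC2)C[C@@H]1c1ccccc1` gives 62 nM, the lowest of the two numbers at hand. Compound 2 `CC(C)(C)OC(=O)N1CC[C@H](c2ccccc2)[C@@H](C(=O)NCc2cc(C(F)(F)F)cc(C(F)(F)F)c2)C1` gives 450 nM in this assay, a gap beyond the scatter, though the two compounds differ in more than one place. Compound 3 `CN(Cc1cc(C(F)(F)F)cc(C(F)(F)F)c1)C(=O)[C@H]1CN(C(=O)c2cnccn2)C[C@@H]1c1ccccc1` differs from compound 1 by (pyrazin-2-yl)carbonyl in place of cyclohexylmethyl on an amine nitrogen in a ring. Among the measured compounds shown here, no measured pair isolates this single change. Compound 3 is expected to give 200 nM in this assay, within 50 nM to 800 nM. The estimated step of a 3.2-fold higher number from compound 1 to compound 3 (0.51 log units; beyond the scatter) is a moderate loss, somewhat beyond the scatter.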

Compound 3, half-maximal inhibitory concentration: 0.74 nM
Compound 3: middle estimate off by 270-fold (2.43 log units), on the high side; measured number below the stated range.
By their numbers in this assay, from the lowest: compound 3; then compound 1; then compound 2.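

In this assay, the ring nitrogen proves highly sensitive to its substituent: (pyrazin-2-yl)carbonyl in place of cyclohexylmethyl gives an 84-fold lower number from compound 1 to compound 3 (1.92 log units; beyond the scatter) and a large gain. Among the compounds shown here, this is the first single-change comparison at this position, and it shows that the cyclohexylmethyl group is not required for strong inhibition. Nothing at hand accounts for the size of the step.

The compounds shown leave open whether the carbonyl or the pyrazine ring drives the gain. A benzoyl or cyclohexylcarbonyl group on the same nitrogen would separate the two.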